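The source may hold more compounds than are shown below. What is called first, only, known or untested is meant among the compounds shown, and "the series" means these compounds.

Measured compounds:
Compound 1 `N#Cc1cccc(C(=O)NC2CCCC(NC(=O)c3ccccn3)C2)c1` — in a functional assay on HEK293 cells for antagonist activity at metabotropic glutamate receptor 5 (Homo sapiens), read by FLIPR and calcium flux (on this read-out higher numbers stand for weaker inhibition and lower numbers for stronger inhibition), compound 1 gives 531 nM.
Compound 2 `CN(C)c1cccc(C(=O)N[C@H]2CCC[C@H](NC(=O)c3cccc(Cl)c3)C2)c1` — in this assay compound 2 gives only a limit of the assay, > 10000 nM.
Compound 3 `O=C(N[C@H]1CCC[C@H](NC(=O)C2CCCCC2)C1)c1cccc(Cl)c1` — in this assay compound 3 gives 857 nM.

Among the numbers shown, compound 1 stands lowest, but its nearest neighbour compound 3 sits within the scatter of it, so no order between the two can be read. Compound 2 is known only as a limit (the limit of > 10000 nM in this assay, at which 1 of the 3 values shown sits). Among the measured compounds shown here, the one step between measured compounds, an at least 11-fold lower number from compound 2 to compound 3 (1.06 log units; beyond the scatter), swaps a substituent on a carbonyl carbon and says nothing about stereochemistry.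

Compound 4 `N#Cc1cccc(C(=O)N[C@@H]2CCC[C@@H](NC(=O)c3ccccn3)C2)c1` differs from compound 1 only in that regard: the two compounds have the same atoms and bonds; at least one stereo element is drawn with a configuration in one of them and without one in the other: 2 of 2 stereo elements differ; a stereocentre at a saturated ring carbon is drawn without a configuration in compound 1 and R in compound 4; a stereocentre at a saturated ring carbon is drawn without a configuration in compound 1 and R in compound 4. For the measured compounds named here, no measured step bears on this change. Since compound 3, which carries defined configurations at both ring carbons, gives 857 nM, a defined pair of centres is compatible with activity in this series; compound 4 is therefore expected to show a modest step, a 1.8-fold lower number from compound 1 to compound 4 (0.25 log units; within the scatter), toward a lower number, with wide uncertainty. Compound 4 is estimated at 300 nM, between 100 nM and 2000 nM.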

Compound 4, half-maximal inhibitory concentration: 231 nM
For compound 4 the middle estimate is 1.3-fold (0.11 log units) above the measured one; measured number inside the range.
By their numbers in this assay, from the lowest: compound 4; then compounds 1 and 3 (each within the scatter of the next). At a limit, above all of these: compound 2.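

In this assay, the stereocentres at the two saturated ring carbons bear on the read-out even with atoms and bonds unchanged, giving a 2.3-fold lower number from compound 1 to compound 4 (0.36 log units; beyond the scatter). Among the compounds shown here, the earlier step concerned only a substituent on a carbonyl carbon, whereas this modest step, beyond the scatter, is the first reading on these stereocentres and shows that R at both is compatible with the lowest number so far. The step can be traced to one difference only: the fact that one of compounds 1 and 4 is drawn with a defined configuration and the other without, at the place where they differ.

The compounds shown leave open how S at either or both of these ring carbons would read, and so whether the undefined drawing of compound 1 hides a configuration with a higher number. They also leave open whether a methoxy group or a fluorine in place of the nitrile would keep that number.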